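Compounds 1 to 3: changing the aryl urea nitrogen

The source may report more compounds than this note shows. Statements on the series, on what has been measured and on what is new or still open speak of the compounds shown alone.

Compound 1 `C=C[C@]1(C)C[C@@H](OC(=O)CNC(=O)Nc2ccc(OC)cc2)[C@]2(C)[C@H](C)CC[C@]3(CCC(=O)[C@H]32)[C@@H](C)[C@@H]1O`: > 10000 nM (a limit of the assay)
Compound 2 `C=C[C@]1(C)C[C@@H](OC(=O)CNC(=O)Nc2cccc(Br)c2)[C@]2(C)[C@H](C)CC[C@]3(CCC(=O)[C@H]32)[C@@H](C)[C@@H]1O`: 3950 nM

Among the compounds with values here, in a functional assay on HGC-27 cells (Homo sapiens) for inhibition, read by MTT assay, with a stated time of 72 h (on this read-out lower numbers stand for stronger inhibition and higher numbers for weaker inhibition), compound 2 gives 3950 nM, the only true number so far. The sole other result is the limit of > 10000 nM in this assay, at which 1 of the 2 values shown sits, and it belongs to compound 1 as a limit.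

Compound 3 `C=C[C@]1(C)C[C@@H](OC(=O)CNC(=O)NC(=O)c2ccc(Br)cc2)[C@]2(C)[C@H](C)CC[C@]3(CCC(=O)[C@H]32)[C@@H](C)[C@@H]1O` carries (4-bromophenyl)carbonyl in place of 3-bromophenyl on an amide-type nitrogen. Within the data shown here, one measured step bears on this nitrogen: an at least 2.5-fold lower number from compound 1 to compound 2 (0.40 log units; beyond the scatter). That step shows that the group held there can move the number in this assay, and compound 2, with 3-bromophenyl, is the better of the two results. Among the measured compounds shown here, no measured compound has a carbonyl at this place, so the evidence is thin. Given an at least 2.5-fold lower number from compound 1 to compound 2 (0.40 log units; beyond the scatter), a modest move toward higher numbers is expected, similar in size to that step. The estimated step is a 2.0-fold higher number from compound 2 to compound 3 (0.31 log units; beyond the scatter). Compound 3 is expected at 8000 nM, with an estimated range of 3000 nM to 20000 nM.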

Compound 3, half-maximal inhibitory concentration: > 10000 nM
Compound 3 ended at the assay's limit; the forecaster's own chance of this, stated with the estimate: 45%; at least 1.2-fold (0.09 log units) between middle value and limit.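

In this assay, the change on the amide-type nitrogen gives an at least 2.5-fold higher number from compound 2 to compound 3 (0.40 log units; beyond the scatter), so (4-bromophenyl)carbonyl does not keep the result that 3-bromophenyl gives at this place. As far as these compounds go, compound 3 gives > 10000 nM, which is a limit of the assay and not a number, so the true size of this loss stays unknown and the step marks only its smallest size. The step between compound 1 and compound 3 cannot be read, and of the three compounds only compound 2 holds a true number: the limit of > 10000 nM in this assay, at which 2 of the 3 values shown sit.

Still open, from the compounds shown here alone, is whether the step belongs to the entering carbonyl or to the change from a 3-bromo to a 4-bromo pattern, a question that 4-bromophenyl or (3-bromophenyl)carbonyl on this same nitrogen would settle. Also open, going by these compounds, is whether a different kind of group on this nitrogen, such as a pyridyl ring, a plain alkyl chain or an aminophenyl group, would give a lower number in this assay than compound 2 does.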